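The compounds below may be only part of what the source reports. "The series", "measured", "known", "first", "only" and "open" are said of these compounds alone.

Working notes on the series.

Three compounds share one core and have been run in an ADME assay on microsomes from liver (Mus musculus) for metabolic stability, read by LC-MS; a lower number here means slower removal, a higher number faster removal of the compound. Compound 1 `CC1CCC(NC(=O)c2cc3c(Cl)cccc3[nH]2)CC1` gives 462 mL.min-1.g-1 in this assay. Compound 2 `CC1CCC(NC(=O)c2cc3cccc(Cl)c3[nH]2)CC1` gives 1040 mL.min-1.g-1, the highest of the three numbers, in this assay. Compound 3 `CC1CCC(NC(=O)c2cc3c(Cl)c(Cl)ccc3[nH]2)CC1` gives 60.8 mL.min-1.g-1 in this assay, the lowest of the three. Compound 1 and compound 2 hold the same atoms joined differently; the difference between the two cores is not broken down here, and only the two values speak for it.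

Among the measured compounds shown here, the one counted step within the measured set is chloro in place of hydrogen on an aromatic carbon, which gave a 7.6-fold lower number from compound 1 to compound 3 (0.88 log units; beyond the scatter) in this assay.

Compound 4 `CC1CCC(NC(=O)c2cc3cc(Cl)cc(Cl)c3[nH]2)CC1` has not yet been measured. It stands to compound 2 as compound 3 stands to compound 1: chloro in place of hydrogen on an aromatic carbon. The surroundings of the place are not identical, though. In compound 3 the entering chloro sits ortho to a chloro group, meta to a fused ring and para to a fused ring; in compound 4 it sits meta to a chloro group, meta to a fused ring and para to a fused ring. This is therefore the same kind of change, not the same change.

Because the earlier step was a 7.6-fold lower number from compound 1 to compound 3 (0.88 log units; beyond the scatter), the step from compound 2 to compound 4 in this assay is expected to be a 4.2-fold lower number from compound 2 to compound 4 (0.62 log units; beyond the scatter), somewhat smaller given the different surroundings. Compound 4 is thus expected to give about 250 mL.min-1.g-1 in this assay, with a likely range from 100 mL.min-1.g-1 to 600 mL.min-1.g-1.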

Compound 4, intrinsic clearance in microsomes: 187 mL.min-1.g-1
Estimate against measurement, compound 4: 1.3-fold (0.13 log units) above, within the range that was stated.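

In this assay chloro in place of hydrogen on an aromatic carbon gave a 5.6-fold lower number from compound 2 to compound 4 (0.75 log units; beyond the scatter) on the second core, so the change carried over between the two cores with no difference in size that can be told apart: the same change on two cores in this assay, a 7.6-fold lower number (0.88 log units; beyond the scatter) from compound 1 to compound 3 and a 5.6-fold lower number (0.75 log units; beyond the scatter) from compound 2 to compound 4, 1.4-fold (0.14 log units) apart, within the scatter of two such steps.

This rests on one pair on each core, and the surroundings of the entering chloro are not identical in the two pairs, so the agreement is a match between two steps and not a rule for other cores or other places on the ring. It also does not show why the number falls, and it cannot separate any contribution of the place from one of the core.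

The compounds shown carry only chloro on the aromatic ring, which leaves open whether fluoro, methoxy or a nitrile in the same place would give a step of similar size. From the compounds shown here alone, the part on the amide nitrogen is the same throughout, so it also stays open how an amine or a hydroxyl group on that part would move the number in this assay and whether the chloro step would hold there.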